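The source may report more compounds than this note shows. Statements on the series, on what has been measured and on what is new or still open speak of the compounds shown alone.

Measured so far in a functional assay on K562 cells (Homo sapiens) for cytotoxicity, read by CCK-8 assay, with a stated time of 72 h; a higher number here means a weaker inhibitor, a lower number a stronger inhibitor:
- compound 1 `C=CCn1c(=O)/c(=C\c2cccc(Cl)c2)[nH]c(=O)/c1=C\c1ccccc1OC`: 2700 nM
- compound 2 `COc1ccccc1/C=c1/[nH]c(=O)/c(=C\c2ccccc2OC)n(C)c1=O`: 2200 nM
- compound 3 `C=CCn1c(=O)/c(=C\c2cc(F)ccc2C)[nH]c(=O)/c1=C\c1ccccc1OC`: 1800 nM

Compound 2 stands second highest of the three numbers, within the scatter of compound 3 on one side and of compound 1 on the other; the three values do not separate.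

Compound 4 `COc1ccccc1/C=c1/[nH]c(=O)/c(=C\c2ccccc2OC)[nH]c1=O` differs from compound 2 by hydrogen in place of methyl on an aromatic nitrogen. For the measured compounds named here, the only single-site step measured, a 1.5-fold lower number from compound 1 to compound 3 (0.18 log units; within the scatter), concerns the aryl group on the double-bonded chain carbon and lies within the scatter; no measured pair touches the substituent on the aromatic nitrogen. Going by the values given here, with no step bearing on this change, no movement beyond the scatter is expected in this assay; the expected step is no change at the digits printed from compound 2 to compound 4 (within the scatter). Compound 4 is expected to give 2200 nM, with a range from 800 nM to 6000 nM.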

Compound 4, half-maximal inhibitory concentration: "not active" (no number reported)
For compound 4 the study gives words and no number, and the estimate cannot be compared.
By their numbers in this assay, from the lowest: compounds 3, 2 and 1 (each within the scatter of the next).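

For the compounds shown here, compound 4 is reported in this assay only as not active, without a number, so no step from compound 2 to compound 4 can be read. No evidence bears on this result. The compounds shown leave open what size of change, if any, hydrogen in place of methyl on the aromatic nitrogen brings.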